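Thioester in place of amide on the shared core

The compounds below may be only part of what the source reports. "The series", "measured", "known", "first", "only" and "open" are said of these compounds alone.

Three compounds share one core and were tested in an assay on membranes from HeLa cells for displacement of a labelled ligand from adenosine receptor A3 (Homo sapiens), read by scintillation counting, with a stated time of 180 min, tested at 1 uM; a higher number here means more inhibition at the concentration tested (going by the name of the read-out), a lower number less inhibition. Compound 1 `CC1=C(C(=O)CC(C)C)C(c2ccsc2)NC(=O)N1` gives 14%. Compound 2 `CC1=C(C(N)=O)C(c2ccsc2)NC(=O)N1` gives 1%, and compound 3 `CC1=C(C(=O)NC(C)C)C(c2ccsc2)NC(=O)N1` gives 1%. Compound 3 thus stands level with compound 2, the two together at the lowest numbers of the three, while the step of a number 13 percentage points lower from compound 1 to compound 3 (beyond the scatter) shows that only the ketone of compound 1 rises out of the scatter.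

Compound 4 `CC1=C(C(=O)SC(C)C)C(c2ccsc2)NC(=O)N1` is not yet measured. It differs from compound 3 in one place: isopropylsulfanyl in place of isopropylamino on a carbonyl carbon. The change removes the amide hydrogen, much as compound 1 has no such hydrogen. The step of no change at the digits printed from compound 2 to compound 3 (within the scatter) shows that adding isopropyl to the amide nitrogen made no difference, whereas the step of a number 13 percentage points lower from compound 1 to compound 3 (beyond the scatter) was modest but beyond the scatter. A small rise is therefore expected for compound 4, though likely within the scatter, as a number 6 percentage points higher from compound 3 to compound 4 (within the scatter). In this assay compound 4 is estimated at 7%, with a range from 0% to 20%.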

Compound 4, a percentage reported as inhibition, at one concentration (the size of the read-out at that concentration, not a potency): 1%
Estimate against measurement, compound 4: 6 percentage points above, within the range that was stated.
By their numbers in this assay, from the lowest: compounds 2, 3 and 4 (each within the scatter of the next); then compound 1.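

In this assay, isopropylsulfanyl in place of isopropylamino gives no change at the digits printed from compound 3 to compound 4 (within the scatter), so taking away the amide hydrogen does not by itself move the number on this carbonyl carbon. Compound 4 lacks that hydrogen just as compound 1 does, yet the step of a number 13 percentage points lower from compound 1 to compound 4 (beyond the scatter) shows that this shared absence does not carry the number of compound 1 over to compound 4. With no change at the digits printed from compound 2 to compound 4 (within the scatter) as well, the plain amide, the isopropyl amide and the thioester stay together, and only the isobutyl ketone stands apart from them.

No measurement at hand explains why these groups read as they do. Still open, on these data alone, is whether an ester oxygen in place of the sulfur, a carboxylic acid, or a longer chain on this carbonyl carbon would stand with compound 1 or with the other three.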